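Methylsulfanyl in place of benzylseleno on the shared core

The source may hold more compounds than are shown below. What is called first, only, known or untested is meant among the compounds shown, and "the series" means these compounds.

Compound 1 `C[Se]/C(=N\C(=O)c1cccs1)NC(=O)c1cccs1` gives 1340 nM in a functional assay on PC-3 cells (Homo sapiens) for cytotoxicity, read by MTT assay, with a stated time of 72 h; on this read-out higher numbers stand for weaker inhibition of growth and lower numbers for stronger inhibition of growth.
Compound 2 `O=C(/N=C(/NC(=O)c1cccs1)[Se]Cc1ccccc1)c1cccs1` gives 49900 nM in this assay.
Compound 3 `CS/C(=N\C(=O)c1cccs1)NC(=O)c1cccs1` is not yet measured.

Compound 2 stands with the highest number of the two measured in this assay; its nearest neighbour is compound 1, and the step of a 37-fold higher number from compound 1 to compound 2 (1.57 log units; beyond the scatter) is large. Compound 3 carries a group of 2 heavy atoms (1 carbon, 1 sulfur; no ring) in place of a group of 8 heavy atoms (7 carbon, 1 selenium; one six-membered aromatic ring of carbon only), on a carbon with a double bond to nitrogen. Among the compounds with values here, the only measured step that bears on this change is a 37-fold higher number from compound 1 to compound 2 (1.57 log units; beyond the scatter), where the phenyl on the saturated chain carbon bound to selenium went with a large rise in the number; compound 3 drops that ring again, and no measured pair tells how sulfur in place of selenium matters. Compound 3 is therefore expected to show a large fall in the number, a 25-fold lower number from compound 2 to compound 3 (1.40 log units; beyond the scatter), towards the value of compound 1. The estimate for compound 3 in this assay is 2000 nM, with a range from 600 nM to 8000 nM.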

Compound 3, concentration for 50% growth inhibition: 39000 nM
The estimate for compound 3 lay 20-fold (1.29 log units) below the measured number; the whole stated range lies below it.
By their numbers in this assay, from the lowest: compound 1; then compounds 3 and 2 (each within the scatter of the next).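

In this assay, within the data shown here, the step of a 29-fold higher number from compound 1 to compound 3 (1.46 log units; beyond the scatter) gives the first reading of sulfur in place of selenium on this carbon with a double bond to nitrogen, and it is large even though neither group carries a ring. The step of a 1.3-fold lower number from compound 2 to compound 3 (0.11 log units; within the scatter) lies within the scatter, so methylsulfanyl in place of the benzylseleno group shows no readable change, and losing the phenyl ring does not by itself bring the number down to that of compound 1. Among these three compounds, only compound 1, with its methyl group on selenium, holds the low number, and no measurement at hand explains why.

As far as these compounds go, what a benzylsulfanyl group would give on the shared core remains open, which leaves the effect of sulfur with the phenyl ring present unknown. Also open, from the compounds shown here alone, is whether an ethyl chain on selenium would stay near compound 1 or move towards compound 2.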